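Extending the second acyl chain of the bis-acylguanidine series

The source may report more compounds than this note shows. Statements on the series, on what has been measured and on what is new or still open speak of the compounds shown alone.

Measured so far:
compound 1 `CC(C)=CCC/C(C)=C/CC/C(C)=C/C(=O)NC(=N)NC(=O)C=C(C)C` — 24200 nM
compound 2 `CC(C)=CCC/C(C)=C/C(=O)NC(=N)NC(=O)C=C(C)C` — 53400 nM

In a functional assay on SK-MEL-28 cells (Homo sapiens) for inhibition, read by MTT assay, with a stated time of 72 h (a higher number here means a weaker inhibitor of growth, a lower number a stronger inhibitor of growth), compound 2 gives 53400 nM, the highest of the two numbers; the nearest is compound 1, which gives 24200 nM. Going by the values given here, the one measured step, a 2.2-fold higher number from compound 1 to compound 2 (0.34 log units; beyond the scatter), shows that removing a 3-methylbut-2-en-1-yl from one acyl chain raises the number by a modest amount, beyond the scatter.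

Compound 3 `CC(C)=CCC/C(C)=C/C(=O)NC(=N)NC(=O)/C=C(\C)CCC=C(C)C` is not yet measured. It differs from compound 2 as follows: 3-methylbut-2-en-1-yl in place of hydrogen on a saturated chain carbon bound to a double-bonded chain carbon. Among the compounds with values here, this is the same group that was lost from compound 1 to compound 2, now added to the other acyl chain of the shared core, so the only step bearing on it is a 2.2-fold higher number from compound 1 to compound 2 (0.34 log units; beyond the scatter). A drop of about that size is expected, at the edge of the scatter, because a 2.2-fold higher number from compound 1 to compound 2 (0.34 log units; beyond the scatter) was itself modest. Compound 3 is therefore estimated at 26000 nM (range 12000 nM to 56000 nM), the expected step being a 2.1-fold lower number from compound 2 to compound 3 (0.31 log units; beyond the scatter).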

Compound 3, concentration for 50% growth inhibition: 61900 nM
Estimate against measurement, compound 3: 2.4-fold (0.38 log units) below, outside the stated range (above it).
By their numbers in this assay, from the lowest: compound 1; then compounds 2 and 3 (each within the scatter of the next).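

In this assay, 3-methylbut-2-en-1-yl on the saturated chain carbon of this second acyl chain gives a 1.2-fold higher number from compound 2 to compound 3 (0.06 log units; within the scatter) and so yields no readable change in growth inhibition at this position. The same group on the other acyl chain of the shared core accounts for a 2.2-fold higher number from compound 1 to compound 2 (0.34 log units; beyond the scatter) in the earlier pair, so its contribution in these two pairs depends on which chain carries it and cannot be carried over from one chain to the other. Nothing available explains this difference between the two chains.

As far as these compounds go, whether an amine or a carboxylic acid in place of 3-methylbut-2-en-1-yl on this carbon would give a step beyond the scatter stays open. Also open, from the compounds shown here alone, is what 3-methylbut-2-en-1-yl on both acyl chains together would give.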